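From chloro to bromo on the benzyl ring

The compounds below may be only part of what the source reports. "The series", "measured", "known", "first", "only" and "open" are said of these compounds alone.

Measured compounds in an assay for inhibition of transient receptor potential cation channel subfamily V member 1 (Rattus norvegicus), with a stated time of 10 min; on this read-out lower numbers stand for stronger inhibition and higher numbers for weaker inhibition:
compound 1, `CS(=O)(=O)Nc1ccc(C/N=C(\S)NCc2ccccc2)cc1F`, gives 9700 nM
compound 2, `CS(=O)(=O)Nc1ccc(C/N=C(\S)NCc2ccc(Cl)cc2)cc1F`, gives 340 nM

Among the two measured compounds, compound 2 stands at the lowest number in this assay, and its nearest neighbour is compound 1, which is separated from it by a step beyond the usual scatter. Within the data shown here, the only measured step is a 29-fold lower number from compound 1 to compound 2 (1.46 log units; beyond the scatter), brought about by chloro in place of hydrogen on an aromatic carbon.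

Compound 3, `CS(=O)(=O)Nc1ccc(C/N=C(\S)NCc2ccc(Br)cc2)cc1F`, has not yet been measured. It differs from compound 2 by bromo in place of chloro on an aromatic carbon. Among the measured compounds shown here, no measured step shows what exchanging one halogen for another does; the one step at hand shows that adding chloro at this place brought a large drop in the number from compound 1 to compound 2, but nothing is known about the further change to bromo.

Compound 3 is therefore expected to land close to compound 2, with an estimated step of a 1.1-fold lower number from compound 2 to compound 3 (0.05 log units; within the scatter), a change within the scatter. The estimate for compound 3 in this assay is 300 nM, with a range from 120 nM to 800 nM.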

Compound 3, half-maximal inhibitory concentration: 570 nM
Compound 3: middle estimate off by 1.9-fold (0.28 log units), on the low side, within the range that was stated.
By their numbers in this assay, from the lowest: compounds 2 and 3 (each within the scatter of the next); then compound 1.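

In this assay, exchanging chloro for bromo on the aromatic carbon para to a large group gives a 1.7-fold higher number from compound 2 to compound 3 (0.22 log units; within the scatter), so on this read-out the two halogens cannot be told apart at this place. Measured against hydrogen at the same place, bromo gives a 17-fold lower number from compound 1 to compound 3 (1.23 log units; beyond the scatter), a large step of the same kind as the earlier one for chloro, a 29-fold lower number from compound 1 to compound 2 (1.46 log units; beyond the scatter), so the large drop in the number is no longer tied to chloro alone but is seen with both halogens. No evidence at hand bears on what lies behind this result.

The compounds shown cover only hydrogen, chloro and bromo at this place, which leaves open whether the drop in the number extends to the smaller fluoro, the larger iodo, or to groups that are not halogens at all, such as methyl, methoxy, an amine or a carboxylic acid. They also leave open whether chloro or bromo would give a step of this size on another carbon of the same ring, or with a different group elsewhere in the shared core.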